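This account rests on a few compounds, and the source may have more. Where it says the series, first, only, none or still open, it means among the compounds named here.

In an ADME assay on HEK-293T cells (Homo sapiens) for inhibition, read by CCK-8 assay, with a stated time of 48 h, tested at 20 uM (on this read-out lower numbers stand for less inhibition of growth and higher numbers for more inhibition of growth at the one concentration tested), compound 1 (`Cc1ccc(S(=O)(=O)Oc2ccccc2/C=C(\C#N)C(=O)Nc2nnc(Cc3ccc(F)cc3)s2)cc1`) gives 16% and compound 2 (`N#C/C(=C\c1ccccc1OS(=O)(=O)c1ccc(Cl)cc1)C(=O)Nc1nnc(Cc2ccc(F)cc2)s1`) gives 6%, two values within the scatter of each other. Compound 3 (`Cc1ccc(Cc2nnc(NC(=O)/C(C#N)=C/c3ccccc3OS(=O)(=O)c3ccc(C)cc3)s2)cc1`) differs from compound 1 in one place: methyl in place of fluoro on an aromatic carbon (methyl in place of fluoro on an aromatic carbon, so 4-fluorobenzyl becomes 4-methylbenzyl). For the measured compounds named here, the only measured step (a number 10 percentage points lower from compound 1 to compound 2 (within the scatter)) lies elsewhere in the molecule, so it is indirect evidence, and it suggests no step beyond the scatter here. The expected step is small (a number 2 percentage points lower from compound 1 to compound 3 (within the scatter)) and stays within the scatter. Compound 3 is therefore estimated at 14% (range 3% to 28%).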

Compound 3, percent growth inhibition at one concentration: 22%
The estimate for compound 3 lay 8 percentage points below the measured number; the measured number falls inside the stated range.
By their numbers in this assay, from the lowest: compounds 2, 1 and 3 (each within the scatter of the next, the first and the last beyond it).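

For the compounds shown here, the earlier pair varied only the ring on the sulfonate, so this is the first reading at the benzyl end of the molecule. In this assay, 4-methylbenzyl in place of 4-fluorobenzyl gives a number 6 percentage points higher from compound 1 to compound 3 (within the scatter), so this swap does not separate the two compounds on growth inhibition. Nothing measured here offers an explanation for this result. On these data alone, what stays open is how this position responds to groups of a different kind: an amine, a carboxylic acid or a methoxy group in the same place could read differently.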